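Removing the hydantoin: solubility outlook for an acetate ester

The source may hold more compounds than are shown below. What is called first, only, known or untested is meant among the compounds shown, and "the series" means these compounds.

Measured compounds so far:
Compound 1 `O=C1O[C@@H](CO)CN1c1ccc(-n2cc(-c3ccccn3)cn2)c(F)c1`: 56400 nM
Compound 2 `O=C1CNC(=O)N1C[C@H]1CN(c2ccc(-n3cc(-c4ccccn4)cn3)c(F)c2)C(=O)O1`: 1630000 nM

Both compounds share one core and were tested in a physicochemical assay for solubility, read by HPLC, with a stated time of 24 h; on this read-out higher numbers stand for higher solubility and lower numbers for lower solubility. Among the measured compounds shown here, compound 2 holds the highest of the two numbers; its nearest neighbour is compound 1, and the one measured step between them, a 29-fold higher number from compound 1 to compound 2 (1.46 log units; beyond the scatter), is large. The unmeasured compound 3 `CC(=O)OC[C@H]1CN(c2ccc(-n3cc(-c4ccccn4)cn3)c(F)c2)C(=O)O1` differs from compound 2 by acetoxy in place of 2,5-dioxoimidazolidin-1-yl on a saturated chain carbon bound to a saturated ring carbon. For the measured compounds named here, the only step that bears on this change is the one from compound 1 to compound 2, where installing the 2,5-dioxoimidazolidin-1-yl group raised this assay strongly. Compound 3 removes that same group and puts in an acetoxy group with no hydrogen-bond donor, so a large fall in this assay is expected, landing near or somewhat under the number for compound 1. The estimated step is a 54-fold lower number from compound 2 to compound 3 (1.74 log units; beyond the scatter). Compound 3 is therefore expected to give about 30000 nM, within a range of 8000 nM to 120000 nM.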

Compound 3, solubility: 373000 nM
Compound 3: middle estimate off by 12-fold (1.09 log units), on the low side, outside the stated range (above it).
By their numbers in this assay, from the lowest: compound 1; then compound 3; then compound 2.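

In this assay the new change reads as a 4.4-fold lower number from compound 2 to compound 3 (0.64 log units; beyond the scatter) and so counts as modest, which means that losing the 2,5-dioxoimidazolidin-1-yl group at this position does not bring the number back down to that of compound 1. Among the compounds shown here, putting acetyl on the oxygen of the hydroxy group gives a 6.6-fold higher number from compound 1 to compound 3 (0.82 log units; beyond the scatter) and is also modest, so 2,5-dioxoimidazolidin-1-yl is not the only group here with a higher number than hydroxy, and acetoxy, with 0 hydrogen-bond donors, is another. Nothing measured here explains this order.

On these data alone, whether the ring of 2,5-dioxoimidazolidin-1-yl or its carbonyl groups matter more remains open, since these three compounds cannot separate them. As far as these compounds go, it is also open where a simple amine, a carboxylic acid or a longer ester chain on this saturated chain carbon would fall in this order.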